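Mirror-image pair in the methoxy series

The source may report more compounds than this note shows. Statements on the series, on what has been measured and on what is new or still open speak of the compounds shown alone.

Three compounds of the shared core have a number in a functional assay on HEK293 cells for agonist activity at Neuronal acetylcholine receptor; alpha4/beta2 (Homo sapiens), read by FLIPR; a higher number here means that more compound is needed for the effect, a lower number that less compound is needed. Going by the values given here, compound 1 `Brc1cncc(N2CC[C@@H]3CN[C@@H]3C2)c1` gives 1000 nM; compound 2 `N#Cc1cncc(N2CC[C@@H]3CN[C@@H]3C2)c1` gives 1900 nM; the one measured step, a 1.9-fold higher number from compound 1 to compound 2 (0.28 log units; within the scatter), stays within the scatter. Compound 3 `COc1cncc(N2CC[C@H]3CN[C@H]3C2)c1` gives 130 nM and stands lowest of the three, with compound 1 nearest at a gap beyond the scatter and compound 2 furthest.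

Compound 4 `COc1cncc(N2CC[C@@H]3CN[C@@H]3C2)c1` is not yet measured. Against compound 3 the change is the two compounds have the same atoms and bonds and differ only in configuration as drawn: 2 of 2 stereo elements differ (all stereocentres are inverted: mirror images); a stereocentre at a saturated ring carbon is drawn S in compound 3 and R in compound 4; a stereocentre at a saturated ring carbon is drawn R in compound 3 and S in compound 4. Among the compounds with values here, no measured step concerns an inversion of configuration, so nothing here tells the size of such a step directly. What the structures do show is that compound 1 and compound 2 are drawn with the same configuration as compound 4, and both sit well above compound 3 in this assay.

Compound 4 is therefore expected to give a higher number than compound 3, estimated at 1200 nM with a range of 150 nM to 6000 nM, the step of a 9.2-fold higher number from compound 3 to compound 4 (0.97 log units; beyond the scatter) being the expectation, because compound 1 of that configuration gives 1000 nM and compound 2 gives 1900 nM. The range is wide since the methoxy group has not been measured in this configuration.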

Compound 4, half-maximal effective concentration: 2700 nM
The estimate for compound 4 lay 2.3-fold (0.35 log units) below the measured number; measured number inside the range.
By their numbers in this assay, from the lowest: compound 3; then compounds 1, 2 and 4 (each within the scatter of the next, the first and the last beyond it).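

Configuration is the largest lever on the shared core seen so far, and the methoxy pair gives its first direct size in this assay with a 21-fold higher number from compound 3 to compound 4 (1.32 log units; beyond the scatter). This step can be assigned to configuration alone, because nothing else in the pair changes, as shown by this: the fact that compounds 3 and 4 differ only in the configuration as drawn

Within the configuration of compound 4, the aromatic substituent has much less reach: methoxy in place of cyano gives a 1.4-fold higher number from compound 2 to compound 4 (0.15 log units; within the scatter) and methoxy in place of bromo gives a 2.7-fold higher number from compound 1 to compound 4 (0.43 log units; beyond the scatter). The low number of compound 3 therefore does not come from the methoxy group alone, since the same group in the inverted configuration gives no such number, and among these compounds it appears only with the methoxy group and the configuration of compound 3 together.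

As far as these compounds go, whether the inversion gives a step of similar size with bromo or cyano on the aromatic carbon stays open, as does the share of each of the two stereocentres in the step. Also open, from the compounds shown here alone, is how an amine or a longer chain on that aromatic carbon would read in either configuration.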